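Carbonyl substituent changes in the amide series

The compounds below may be only part of what the source reports. "The series", "measured", "known", "first", "only" and "open" are said of these compounds alone.

Compound 3 `C=CC(=O)N(Cc1ccc(OC)c(O)c1)c1cc(OC)c(OC)c(OC)c1` gives the lowest of the three measured numbers in a functional assay on HCT-116 cells (Homo sapiens) for inhibition, read by MTT assay, with a stated time of 48 h (on this read-out lower numbers stand for stronger inhibition and higher numbers for weaker inhibition), at 98 nM. Compound 1 `COc1ccc(CN(C(=O)CCl)c2cc(OC)c(OC)c(OC)c2)cc1O` gives 250 nM and compound 2 `COc1ccc(CN(C(=O)C[Se]C#N)c2cc(OC)c(OC)c(OC)c2)cc1O` gives 310 nM; the step of a 1.2-fold higher number from compound 1 to compound 2 (0.09 log units; within the scatter) lies within the scatter. The steps of a 2.6-fold lower number from compound 1 to compound 3 (0.41 log units; beyond the scatter) and a 3.2-fold lower number from compound 2 to compound 3 (0.50 log units; beyond the scatter) both sit on the carbonyl carbon and both reach a modestly lower number once vinyl is in place. Compound 4 `COc1ccc(CN(C(=O)CO)c2cc(OC)c(OC)c(OC)c2)cc1O` differs from compound 3 by hydroxymethyl in place of vinyl on a carbonyl carbon. Going by the values given here, no measured step involves hydroxymethyl; the two steps at the carbonyl carbon show vinyl giving the lower number against either alternative tried there. For compound 4 a higher number than for compound 3 is therefore expected, a 7.1-fold higher number from compound 3 to compound 4 (0.85 log units; beyond the scatter), with the estimate 700 nM and a range from 250 nM to 3000 nM.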

Compound 4, half-maximal inhibitory concentration: 520 nM
Estimate against measurement, compound 4: 1.3-fold (0.13 log units) above, within the range that was stated.
By their numbers in this assay, from the lowest: compound 3; then compounds 1, 2 and 4 (each within the scatter of the next, the first and the last beyond it).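

Hydroxymethyl, which enters with a hydrogen-bond donor and acceptor, also gives a higher number than vinyl on the carbonyl carbon (a 5.3-fold higher number from compound 3 to compound 4 (0.72 log units; beyond the scatter)), so vinyl now stands lowest against all three alternatives shown. On the saturated chain carbon bound to the carbonyl carbon, hydroxy in place of chloro gives a modest rise (a 2.1-fold higher number from compound 1 to compound 4 (0.32 log units; beyond the scatter)), whereas hydroxy in place of the selenium-bearing group stays within the scatter (a 1.7-fold higher number from compound 2 to compound 4 (0.22 log units; within the scatter)). Nothing available explains these differences.

Open, as far as these compounds go, is how an amine, a carboxylic acid or a longer chain on the carbonyl carbon would compare with vinyl in compound 3. Open too, from the compounds shown here alone, is whether the lower number with vinyl persists when the rest of the core changes.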